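Allyl for ethyl on the shared core

This account rests on a few compounds, and the source may have more. Where it says the series, first, only, none or still open, it means among the compounds named here.

Compound 1 `CCNc1n[n+]([O-])c2ccccc2[n+]1[O-]` gives 4500 nM
Compound 2 `O=[N+]([O-])c1ccc(CNc2n[n+]([O-])c3ccccc3[n+]2[O-])cc1` gives 3100 nM
Compound 3 `Cc1ccc(Nc2n[n+]([O-])c3ccccc3[n+]2[O-])cc1` gives 2500 nM

In a functional assay on K562 cells (Homo sapiens) for cytotoxicity, read by MTT assay, with a stated time of 48 h (on this read-out lower numbers stand for stronger inhibition and higher numbers for weaker inhibition), these three values lie within the usual scatter of each other, so the numbers set no order among them, and compound 1 stands level with the other two. Compound 4 `C=CCNc1n[n+]([O-])c2ccccc2[n+]1[O-]` differs from compound 1 in one place vinyl in place of methyl on a saturated chain carbon bound to a nitrogen on an aromatic ring and this is vinyl in place of methyl on a saturated chain carbon bound to a nitrogen on an aromatic ring. For the measured compounds named here, no measured pair shows this change alone. Going by the values given here, the only guide is that compound 2 at 3100 nM and compound 3 at 2500 nM carry different groups and remain within the scatter of compound 1. In this assay no change beyond the scatter is expected. The estimated step of a 1.3-fold lower number from compound 1 to compound 4 (0.11 log units; within the scatter) is expected to stay within that scatter. Compound 4 is estimated at 3500 nM with an expected range of 1800 nM to 7000 nM.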

Compound 4, half-maximal inhibitory concentration: 11200 nM
Compound 4: the middle estimate sits 3.2-fold (0.51 log units) below what was measured, and the stated range ends below it.
By their numbers in this assay, from the lowest: compounds 3, 2 and 1 (each within the scatter of the next); then compound 4.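

In this assay, replacing ethylamino with allylamino gives a 2.5-fold higher number from compound 1 to compound 4 (0.40 log units; beyond the scatter) and so weaker inhibition. For the compounds shown here, this modest step is the first reading of a single change on the shared core, and it shows that this saturated chain carbon is sensitive to vinyl in place of methyl. Nothing available explains the step.

The compounds shown leave open whether the double bond or the added chain length goes with this step, a question a propyl group in the same place could help separate. Going by these compounds, how an amine at the end of the chain would read also remains open.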